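A few compounds are considered here, and "the series" means these few. Any claim that something is new, unique, unknown or untested is made for them only; others in the source may bear on it.

Measured so far in a functional assay on HEK293 cells for agonist activity at Free fatty acid receptor 1 (Homo sapiens), read by HTRF and inositol phosphate accumulation, with a stated time of 60 min; on this read-out lower numbers stand for an effect already at smaller amounts and higher numbers for an effect only at larger amounts of compound:
Compound 1 `COc1cc(OC(F)(F)F)cc(-c2ccc3c(c2)CC[C@H](CCc2nnn[nH]2)O3)c1F` gives > 10000 nM, a limit of the assay.
Compound 2 `Fc1ccc(OC(F)(F)F)cc1-c1ccc2c(c1)CC[C@H](CCc1nnn[nH]1)O2` gives > 10000 nM, likewise a limit.
Compound 3 `O=C(O)CC[C@H]1CCc2cc(-c3cc(OC4CCC4)ccc3F)ccc2O1` gives 3600 nM.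

Compound 1 thus stands only at a limit in this assay. Among the measured compounds shown here, the one measured step that touches it, a step that the two limits leave unreadable from compound 1 to compound 2, cannot be sized, since both ends sit at the limit of > 10000 nM in this assay, at which 2 of the 3 values shown sit. Compound 4 `COc1cc(OC2CC2)cc(-c2ccc3c(c2)CC[C@H](CCc2nnn[nH]2)O3)c1F` differs from compound 1 by cyclopropyl in place of trifluoromethyl on an oxygen on an aromatic ring. For the measured compounds named here, no measured pair shows this exchange; compound 3 shows only that an analogue carrying a cyclobutyloxy group and a different acidic chain gives a readable number. The expected step from compound 1 to compound 4 is therefore an at least 1.2-fold lower number from compound 1 to compound 4 (0.09 log units; that floor lies within the scatter), with its direction uncertain and a fair chance that the assay again reports only a limit. Compound 4 is estimated at 8000 nM in this assay, within a range of 2000 nM to 30000 nM.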

Compound 4, half-maximal effective concentration: > 10000 nM
Compound 4: a limit, no number (the forecaster's own chance of this, stated with the estimate: 55%); middle value at least 1.2-fold (0.09 log units) away from the limit.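

Compound 1 and compound 4 both give only a limit, so no step between them can be read: the limit of > 10000 nM in this assay, at which 3 of the 4 values shown sit.

The compounds shown leave open how trifluoromethoxy and cyclopropyloxy compare on the shared core.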